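Piperidinyl Replaces Hydroxy on the Chain of Compound 3

The source may hold more compounds than are shown below. What is called first, only, known or untested is meant among the compounds shown, and "the series" means these compounds.

Measured so far:
- compound 1, `COc1cc(N)c(Cl)cc1C(=O)NCC1CCNCC1`: in a functional assay on HEK293 cells for activation of 5-hydroxytryptamine receptor 4 (Homo sapiens), read by cAMP accumulation (a lower number here means a smaller maximal response, a higher number a larger maximal response), compound 1 gives 81%.
- compound 2, `COc1cc(N)c(Cl)cc1C(=O)NC1CCNCC1`: compound 2 gives > 100%, which is a limit of the assay and not a number.
- compound 3, `COc1cc(N)c(Cl)cc1C(=O)NC1CCN(CCCCCO)CC1`: compound 3 gives > 100%, again a limit of the assay, not a number.

So for compound 3 only a limit is known in this assay, not a value; (the limit of > 100% in this assay, at which 2 of the 3 values shown sit). The step that the two limits leave unreadable from compound 2 to compound 3 has no readable size; both of its ends are limits.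

Compound 4, `COc1cc(N)c(Cl)cc1C(=O)NC1CCN(CCCCCN2CCCCC2)CC1`, differs from compound 3 by piperidin-1-yl in place of hydroxy on a saturated chain carbon, five bonds along the chain from an amine nitrogen in a ring.

Among the measured compounds shown here, the one measured step, a step that the two limits leave unreadable from compound 2 to compound 3, concerns the chain on the same ring nitrogen, and it gives no readable size, so nothing measured speaks for a move in either direction beyond the scatter. The expectation is that compound 4 stays near the top of the scale, with an estimated step of a number no higher from compound 3 to compound 4 (the limit leaves the size open). Compound 4 is therefore estimated at 100%, in a range from 80% to 120%.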

Compound 4, intrinsic activity: the largest response reached, in percent of the reference agonist's: > 100%
Compound 4: a limit, no number; the forecaster's own chance of this, stated with the estimate: 50%; the middle value sits exactly at the limit.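

Compound 4 gives > 100%, which is a limit of the assay and not a number. Among the compounds shown here, compound 3 sits at the same limit, so no step between compound 3 and compound 4 can be read: the limit of > 100% in this assay, at which 3 of the 4 values shown sit. The compounds shown leave open whether piperidin-1-yl in place of hydroxy changes the maximal response at all.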